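The source may report more compounds than this note shows. Statements on the series, on what has been measured and on what is new or still open speak of the compounds shown alone.

Measured compounds and their values in an assay for inhibition of tRNA (cytosine(38)-C(5))-methyltransferase (Homo sapiens), with a stated time of 5 min, tested at 100 uM; a lower number here means less inhibition, a higher number more inhibition at the concentration tested (going by the name of the read-out):
- compound 2, `Nc1ncnc2c1ncn2[C@@H]1O[C@H](CN(CC[C@H](N)C(=O)O)CC2CCC2)[C@@H](O)[C@H]1O`: 32%
- compound 3, `Nc1ncnc2c1ncn2[C@@H]1O[C@H](CN(CC[C@H](N)C(=O)O)CC2CCCC2)[C@@H](O)[C@H]1O`: 24.5%
- compound 1, `NCCCSC[C@H]1O[C@@H](n2cnc3c(N)ncnc32)[C@H](O)[C@@H]1O`: no result reported

Compound 3 gives the lowest of the two numbers available in this assay, with compound 2 the nearest at a number higher by the step of a number 7.5 percentage points lower from compound 2 to compound 3 (within the scatter), which lies within the scatter of repeated measurements. Compound 1 carries no value in this assay, so nothing can be drawn from it.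

The compound now to be measured is compound 4, `CCC#CCN(CC[C@H](N)C(=O)O)C[C@H]1O[C@@H](n2cnc3c(N)ncnc32)[C@H](O)[C@@H]1O`. It differs from compound 3 in one place: but-1-yn-1-yl in place of cyclopentyl on a saturated chain carbon bound to an amine nitrogen.

Within the data shown here, only one measured step is available to bear on this change, the step from compound 2 to compound 3, which stayed within the scatter when the ring on the saturated chain carbon bound to the amine nitrogen was enlarged by one carbon. Among the measured compounds shown here, the change to compound 4 is of another kind, exchanging that ring for an open chain with a triple bond, and no measured pair shows such a swap. With no step beyond the scatter in the data, compound 4 is expected to stay close to compound 3, with a step of about a number 0.5 percentage points higher from compound 3 to compound 4 (within the scatter) in this assay. Compound 4 is therefore estimated at 25%, between 8% and 45%.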

Compound 4, a percentage reported as inhibition, at one concentration (the size of the read-out at that concentration, not a potency): 62.8%
Compound 4: middle estimate off by 37.8 percentage points, on the low side; the measured number lies above the stated range.
By their numbers in this assay, from the lowest: compounds 3 and 2 (each within the scatter of the next); then compound 4.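

In this assay this position proves able to move the read-out well beyond the scatter: putting but-1-yn-1-yl in place of cyclopentyl gives a number 38.3 percentage points higher from compound 3 to compound 4 (beyond the scatter) in this series, and putting it in place of cyclobutyl gives a number 30.8 percentage points higher from compound 2 to compound 4 (beyond the scatter) in the same direction. The earlier pair had shown only that enlarging the ring by one carbon gives a number 7.5 percentage points lower from compound 2 to compound 3 (within the scatter) and so no clear change, whereas the open chain with its triple bond stands apart from both ring compounds. No measurement shown explains this rise, and nothing here offers a reason for it.

Going by these compounds, what remains open is whether the higher number goes with the triple bond itself or simply with the loss of the ring, a question that a saturated butyl or pentyl group at this place would address. On these data alone, it is also open how a longer chain with a triple bond, or one ending in an amine or a carboxylic acid, would read at this position.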